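The source may report more compounds than this note shows. Statements on the series, on what has been measured and on what is new or still open speak of the compounds shown alone.

Of the compounds shown here, two built on a shared core have been measured so far in a functional assay on NCI-H460 cells (Homo sapiens); a higher number here means that more compound is needed for the effect, a lower number that less compound is needed. In this assay, compound 1 `COc1cc(C2OC(c3cccc(N(C)C)c3)=NN2C(C)=O)cc(OC)c1OC` gives 0.26 uM, while compound 2 `CCOC(=O)C(=O)N1N=C(c2ccc(N(C)C)cc2)OC1c1cc(OC)c(OC)c(OC)c1` gives 33 uM. Compound 2 therefore holds the higher of the two numbers, and the gap between them lies beyond the usual scatter.

Compound 3 `COc1cc(C2OC(c3ccc(N(C)C)cc3)=NN2C(=O)CN(C)C)cc(OC)c1OC` has not yet been measured. It differs from compound 2 in one place: (dimethylamino)methyl stands in place of ethoxycarbonyl on a carbonyl carbon ((dimethylamino)methyl in place of ethoxycarbonyl on a carbonyl carbon). Going by the values given here, no measured pair of compounds differs in only one place, so the data offer no direct guide to the size of this change. The expectation rests only on the range set by compound 1 at 0.26 uM and compound 2 at 33 uM, with compound 3 expected to fall inside it. The expected direction is therefore towards a lower number, and the estimated step, an 11-fold lower number from compound 2 to compound 3 (1.04 log units; beyond the scatter), is expected to lie beyond the scatter. In this assay, compound 3 is estimated at 3 uM, with an expected range from 0.4 uM to 25 uM.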

Compound 3, concentration for half-maximal effect: 74 uM
Beside the measured number, compound 3's estimate is 25-fold (1.39 log units) below it; measured number above the stated range.
By their numbers in this assay, from the lowest: compound 1; then compound 2; then compound 3.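

Going by these compounds alone, the step at the carbonyl carbon whose other neighbour is the amide-type nitrogen in a ring gives the first direct reading of a single change in this assay: (dimethylamino)methyl in place of ethoxycarbonyl gives a 2.2-fold higher number from compound 2 to compound 3 (0.35 log units; beyond the scatter). The step is modest but beyond the scatter, so exchanging ethoxycarbonyl, with its 5 heavy atoms and 2 oxygens, for the 4 heavy atoms of (dimethylamino)methyl, which include 1 nitrogen, does not lower the number at this position, and compound 3 stands at 74 uM. Nothing available accounts for the direction or size of this step.

The compounds shown leave open how a cyclic amine such as morpholinomethyl, a longer chain such as 2-(dimethylamino)ethyl, or a carboxylic acid would read on this same carbonyl carbon. Going by these compounds, whether the exchange of ethoxycarbonyl for (dimethylamino)methyl would give a step of similar size and direction on the rest of compound 1 also remains open, since this single step comes from one pair on one background.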